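A few compounds are considered here, and "the series" means these few. Any claim that something is new, unique, unknown or untested is made for them only; others in the source may bear on it.

Compound 1 `C=C(Br)C(=O)Nc1ccc(/C=C/C(=O)c2ccccc2)cc1` gives 3900 nM in a functional assay on FM3A cells (Mus musculus) for antiproliferative activity, with a stated time of 48 h; on this read-out lower numbers stand for stronger inhibition and higher numbers for weaker inhibition. Compound 2 `C=C(Br)C(=O)Nc1ccc(/C=C/C(=O)c2ccc(OC)cc2)cc1` gives 1200 nM in this assay. Compound 3 `C=C(Br)C(=O)Nc1ccc(C(=O)/C=C/c2cccc(OC)c2)cc1` gives 1800 nM in this assay.

Compounds 1 and 2 share a core and differ by methoxy in place of hydrogen on an aromatic carbon, which gave a 3.3-fold lower number from compound 1 to compound 2 (0.51 log units; beyond the scatter). Compound 3 has another core; how it differs from the core of compound 1 is not broken down here. Compound 4 `C=C(Br)C(=O)Nc1ccc(C(=O)/C=C/c2cc(OC)cc(OC)c2)cc1` arises from compound 3 by methoxy in place of hydrogen on an aromatic carbon. This is the same kind of change as from compound 1 to compound 2, but not the same: in compound 2 the methoxy sits para to a large group, in compound 4 it sits meta to a large group and meta to a methoxy group. Because a 3.3-fold lower number from compound 1 to compound 2 (0.51 log units; beyond the scatter) went beyond the scatter, a somewhat smaller step, a 1.8-fold lower number from compound 3 to compound 4 (0.26 log units; within the scatter), is expected for compound 4, as the place differs. Compound 4 is thus estimated at 1000 nM, between 400 nM and 2500 nM.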

Compound 4, half-maximal inhibitory concentration: 2000 nM
For compound 4 the middle estimate is 2.0-fold (0.30 log units) below the measured one; low and high end bracket the measured number.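

In this assay, adding a further methoxy group to the core of compound 3 brought no change that stands out from the scatter: a 1.1-fold higher number from compound 3 to compound 4 (0.05 log units; within the scatter). The gain seen on the core of compound 1 therefore did not carry over to this second core, and the two steps truly differ: the same change on two cores in this assay, a 3.3-fold lower number (0.51 log units; beyond the scatter) from compound 1 to compound 2 and a 1.1-fold higher number (0.05 log units; within the scatter) from compound 3 to compound 4, 3.6-fold (0.56 log units) apart, beyond the scatter of two such steps. This does not show why, as the cores differ and the methoxy also sits in a different place, so with one pair each the effect of core and of place cannot be told apart.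

Open, as far as these compounds go, is whether a methoxy in the same place on both cores would give matching steps. Also open, from the compounds shown here alone, is how another group, such as a hydroxyl or a chlorine atom, would behave on each core.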